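The source may hold more compounds than are shown below. What is called first, only, known or untested is meant among the compounds shown, and "the series" means these compounds.

In a functional assay on A549 cells (Homo sapiens) for cytotoxicity, read by XTT assay, with a stated time of 72 h (a lower number here means a stronger inhibitor, a higher number a weaker inhibitor), compound 1 `CCCCCCCC/C=C\CCCCCCCCOc1cc(O)c(C(C)=O)c(O)c1` gives 31000 nM. Compound 2 `CCCCCCCCCCCCCCCCCCc1c(O)cc(O)c(C(C)=O)c1O` gives 32000 nM, and the two values lie within the usual scatter of each other, so neither compound stands apart from the other on these numbers. Compound 3 `CCCCCCCCCCCCCCCCCCOc1cc(O)c(C(C)=O)c(O)c1` has not yet been measured. It keeps the core of compound 1 and differs only in its chain: decyl in place of dec-1-en-1-yl on a saturated chain carbon, eight bonds along the chain from an oxygen on an aromatic ring, with decyl in place of dec-1-en-1-yl on a saturated chain carbon, eight bonds along the chain from an oxygen on an aromatic ring. Within the data shown here, no measured pair isolates this change, so the data offer no direct guide to its size. With only these two close values to go on, no step beyond the scatter is expected in this assay, in either direction. The estimated step of a 1.1-fold higher number from compound 1 to compound 3 (0.05 log units; within the scatter) therefore stays small. Compound 3 is expected at 35000 nM, with an estimated range of 15000 nM to 80000 nM.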

Compound 3, half-maximal inhibitory concentration: > 100000 nM
Compound 3 was reported as a limit (the forecaster's own chance of this, stated with the estimate: 20%); middle value at least 2.8-fold (0.45 log units) from the limit.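

In this assay, putting decyl in place of dec-1-en-1-yl, on a saturated chain carbon, eight bonds along the chain from an oxygen on an aromatic ring, gives an at least 3.2-fold higher number from compound 1 to compound 3 (0.50 log units; beyond the scatter). The chain at this position is therefore not indifferent: losing the one double bond outside aromatic rings goes with a difference beyond the scatter, which the earlier values did not show. The step is a bound rather than a size, since the value of compound 3 is a limit: the limit of > 100000 nM in this assay, at which 1 of the 3 values shown sits.

On these data alone, how far the step truly reaches stays open. Also open, as far as these compounds go, is how this assay would respond to a shorter chain, or to a chain ending in a carboxylic acid or an amine, at this place.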